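The source may report more compounds than this note shows. Statements on the series, on what has been measured and on what is new or still open speak of the compounds shown alone.

Working notes on the series. Compound 2 `CC(=O)Oc1ccccc1C(=O)O[C@H]1CO[C@H]2[C@@H]1OC[C@H]2O`, which carries a free hydroxy on the shared core, gives 0.0183 h in an ADME assay on a cell-free system (plasma, Homo sapiens) for metabolic stability, with Plasma (Rattus norvegicus) as the target, read by HPLC, at pH 7.4 (a lower number here means that the compound disappears faster, a higher number that the compound lasts longer), the highest of the three numbers at hand. Compound 1 `CC(=O)Oc1ccccc1C(=O)O[C@H]1CO[C@H]2[C@@H]1OC[C@H]2OC(=O)c1snnc1C` gives 0.0065 h and compound 3 `CCC(=O)O[C@@H]1CO[C@H]2[C@@H]1OC[C@@H]2OC(=O)c1ccccc1OC(C)=O` gives 0.011 h. Compound 4 `CC(=O)Oc1ccccc1C(=O)O[C@H]1CO[C@H]2[C@@H]1OC[C@H]2OC(=O)c1ccncc1` differs from compound 2 by (pyridin-4-yl)carbonyl in place of hydrogen on an oxygen on a saturated carbon. Within the data shown here, two measured steps bear on this change: a 2.8-fold higher number from compound 1 to compound 2 (0.45 log units; beyond the scatter), and a 1.7-fold lower number from compound 2 to compound 3 (0.22 log units; within the scatter). Both replacements of that hydrogen by a carbonyl group gave lower numbers, the (4-methyl-1,2,3-thiadiazol-5-yl)carbonyl of compound 1 beyond the scatter, the propanoyl of compound 3 within it. For compound 4 a lower number in this assay is therefore expected, roughly a 2.3-fold lower number from compound 2 to compound 4 (0.36 log units; beyond the scatter). Compound 4 is estimated at 0.008 h, with a range of 0.004 h to 0.016 h.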

Compound 4, half-life: 0.0055 h
For compound 4 the middle estimate is 1.5-fold (0.16 log units) above the measured one; measured number inside the range.
By their numbers in this assay, from the lowest: compounds 4, 1, 3 and 2 (each within the scatter of the next, the first and the last beyond it).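

In this assay, (pyridin-4-yl)carbonyl on this oxygen gives a 3.3-fold lower number from compound 2 to compound 4 (0.52 log units; beyond the scatter) and is the second replacement of the hydrogen to fall beyond the scatter, with compound 3 the exception within it. The carbonyl groups themselves separate little, since a 2.0-fold lower number from compound 3 to compound 4 (0.30 log units; within the scatter) and a 1.2-fold lower number from compound 1 to compound 4 (0.07 log units; within the scatter) are both printed as within the scatter. Nothing at hand accounts for these numbers. Open, going by these compounds, is how a methyl ether or an amine in place of the hydroxy would read, and whether a longer chain on the carbonyl would keep the number near that of compound 2.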